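Amide aryl swap in a flavonol series against HeLa cells

This account rests on a few compounds, and the source may have more. Where it says the series, first, only, none or still open, it means among the compounds named here.

Compound 1 `COc1ccc(C(=O)Nc2cccc(-c3oc4cc(-c5ccc(F)cc5)ccc4c(=O)c3O)c2)cc1` gives 4820 nM in a functional assay on HeLa cells (Homo sapiens) for antiproliferative activity, read by CCK-8 assay, with a stated time of 72 h; a higher number here means a weaker inhibitor, a lower number a stronger inhibitor. Compound 2 `O=C(Nc1cccc(-c2oc3cc(-c4ccc(F)cc4)ccc3c(=O)c2O)c1)c1ccc(C(F)(F)F)cc1` gives 17400 nM, and compound 3 `COc1ccc(C(=O)Nc2cccc(-c3oc4cc(-c5ccc(F)cc5)ccc4c(=O)c3O)c2)c(F)c1` gives 16100 nM, the second highest of the three numbers, close to compound 2 and well apart from compound 1. The steps of a 3.6-fold higher number from compound 1 to compound 2 (0.56 log units; beyond the scatter) and a 3.3-fold higher number from compound 1 to compound 3 (0.52 log units; beyond the scatter) were both modest, while a 1.1-fold lower number from compound 2 to compound 3 (0.03 log units; within the scatter) lay within the scatter. Compound 4 `O=C(Nc1cccc(-c2oc3cc(-c4ccc(F)cc4)ccc3c(=O)c2O)c1)c1ccc(-c2ccccc2)cc1` differs from compound 3 by 4-phenylphenyl in place of 2-fluoro-4-methoxyphenyl on a carbonyl carbon. Among the compounds with values here, no measured step removes both the methoxy and the fluoro or brings in a second ring, so the measured steps bear on this change only indirectly; each departure from compound 1 raised the number. For compound 4 the expected step is a 1.1-fold lower number from compound 3 to compound 4 (0.03 log units; within the scatter), within the scatter. Compound 4 is therefore estimated at 15000 nM, between 5000 nM and 45000 nM.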

Compound 4, half-maximal inhibitory concentration: > 100000 nM
Compound 4: only a limit was reported; the forecaster's own chance of this, stated with the estimate: 10%; middle value at least 6.6-fold (0.82 log units) from the limit.
By their numbers in this assay, from the lowest: compound 1; then compounds 3 and 2 (each within the scatter of the next). At a limit, above all of these: compound 4.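

Compound 4 gives only a limit in this assay, > 100000 nM, and not a number. At this carbonyl carbon, 4-phenylphenyl with its two aromatic rings gave an at least 6.2-fold higher number from compound 3 to compound 4 (0.79 log units; beyond the scatter), and phenyl in place of trifluoromethyl gave an at least 5.7-fold higher number from compound 2 to compound 4 (0.75 log units; beyond the scatter), so this position tolerates the second ring less well than any earlier change. Phenyl in place of methoxy gave an at least 20-fold higher number from compound 1 to compound 4 (1.31 log units; beyond the scatter), the first large step in the set. On these data alone, whether the second ring itself or the loss of methoxy matters more stays open. So does how an amine or a carboxylic acid on this aryl group would behave.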